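From 3-methylphenyl to 4-fluorophenyl on the propyl compound

This account rests on a few compounds, and the source may have more. Where it says the series, first, only, none or still open, it means among the compounds named here.

In a functional assay on MCF7 cells (Homo sapiens) for antiproliferative activity, read by sulforhodamine B assay, with a stated time of 48 h (on this read-out lower numbers stand for stronger inhibition and higher numbers for weaker inhibition), compound 1 (`Cc1cccc(OS(=O)(=O)c2ccc(N3CCN(C)C3=O)cc2)c1`) gives 5100 nM while compound 2 (`CCN1CCN(c2ccc(S(=O)(=O)Oc3cccc(OC)c3)cc2)C1=O`) gives 14000 nM and compound 3 (`CCCN1CCN(c2ccc(S(=O)(=O)Oc3cccc(C)c3)cc2)C1=O`) gives 86000 nM as the highest of the three numbers. Compound 2 is the nearest to compound 3 on these values, and that gap lies beyond the scatter, as does the wider gap to compound 1.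

Compound 4 (`CCCN1CCN(c2ccc(S(=O)(=O)Oc3ccc(F)cc3)cc2)C1=O`) keeps the propyl chain of compound 3 and differs on the oxygen whose other neighbour is the sulfonyl sulfur: 4-fluorophenyl in place of 3-methylphenyl (4-fluorophenyl in place of 3-methylphenyl on an oxygen).

Going by the values given here, the one measured single-place step is a 17-fold higher number from compound 1 to compound 3 (1.23 log units; beyond the scatter) and it lies on the chain, so it does not measure this exchange. Among the compounds with values here, it shows only that one change can move the number a long way here, which argues for a wide range. Within the data shown here, no measured step covers a change of this aromatic group. With compound 3 at 86000 nM at the top of the measured numbers, any expected move is more likely downward. In this assay the expected change is a 2.5-fold lower number from compound 3 to compound 4 (0.39 log units; beyond the scatter) and remains uncertain in size. In this assay compound 4 is estimated at 35000 nM with 9000 nM to 120000 nM as the expected range.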

Compound 4, half-maximal inhibitory concentration: 33000 nM
For compound 4 the middle estimate is 1.1-fold (0.03 log units) above the measured one; low and high end bracket the measured number.
By their numbers in this assay, from the lowest: compound 1; then compound 2; then compound 4; then compound 3.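

In this assay the exchange of 3-methylphenyl for 4-fluorophenyl gives a 2.6-fold lower number from compound 3 to compound 4 (0.42 log units; beyond the scatter) as the first measured move at this place, so the group on the oxygen whose other neighbour is the sulfonyl sulfur does bear on the number for the propyl compound. The chain step (a 17-fold higher number from compound 1 to compound 3 (1.23 log units; beyond the scatter)) remains the larger of the two steps, so this exchange on the propyl compound does not undo a move of that size. Both groups have the same heavy-atom count and the same single aromatic ring of carbon only, and nothing at hand accounts for the step.

As far as these compounds go, whether 4-fluorophenyl would give a step of like size on the methyl compound, compound 1, stays open, since the chain and the oxygen-bound group are each read here on a separate pair. Also open, from the compounds shown here alone, is how this place would respond to a phenyl group carrying an amine or a carboxylic acid, and how the number would move with a longer chain in place of propyl.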